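From Formyl to Acetyl: An Expected Standstill

The compounds below may be only part of what the source reports. "The series", "measured", "known", "first", "only" and "open" are said of these compounds alone.

Compound 1 (`CC(C)(C)OC(=O)N1CCC[C@H]1COCCCCCCCCC/C=C/c1ccc(-c2ccccc2)cc1`) gives 60000 nM in a functional assay on BXPC-3 cells (Homo sapiens) for inhibition, read by XTT assay, with a stated time of 72 h (on this read-out higher numbers stand for weaker inhibition and lower numbers for stronger inhibition), while compound 2 (`O=CN1CCC[C@H]1COCCCCCCCCC/C=C/c1ccc(-c2ccccc2)cc1`) gives 66700 nM there. Going by the values given here, the two numbers lie within the scatter of each other, so compound 2 stands level with compound 1 on the only two values available. Compound 3 (`CC(=O)N1CCC[C@H]1COCCCCCCCCC/C=C/c1ccc(-c2ccccc2)cc1`) has not yet been measured. It departs from compound 2 by methyl in place of hydrogen on a carbonyl carbon with methyl in place of hydrogen on a carbonyl carbon, which turns formyl to acetyl. Among the compounds with values here, one measured step bears on this change, at the same carbonyl carbon: hydrogen in place of tert-butoxy gave a 1.1-fold higher number from compound 1 to compound 2 (0.05 log units; within the scatter) even though tert-butoxy is a larger group than methyl. On that single step, no change beyond the scatter is expected in this assay and no direction can be named. The expected step is a 1.1-fold lower number from compound 2 to compound 3 (0.02 log units; within the scatter) on this estimate. Compound 3 is therefore expected at 63000 nM within an estimated range from 30000 nM to 130000 nM on repeated measurement.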

Compound 3, half-maximal inhibitory concentration: 56700 nM
Compound 3: middle estimate off by 1.1-fold (0.05 log units), on the high side, and the stated range covers the measured number.
By their numbers in this assay, from the lowest: compounds 3, 1 and 2 (each within the scatter of the next).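

With methyl on the carbonyl carbon, whose other neighbour is the amide-type nitrogen in a ring, this assay gives a 1.2-fold lower number from compound 2 to compound 3 (0.07 log units; within the scatter), so adding this single carbon to the formyl group leaves the read-out where it was. Going by these compounds alone, the second step, a 1.1-fold lower number from compound 1 to compound 3 (0.02 log units; within the scatter), shows the same for methyl in place of tert-butoxy, which means that hydrogen, methyl and tert-butoxy at this position now all stand within the scatter of one another, a flat picture that the single earlier step could only suggest and that holds for these three compounds alone. Nothing among the available data accounts for this lack of response at the carbonyl carbon.

The compounds shown leave open whether an amino group, a carboxylic acid or a longer alkyl chain on this carbonyl carbon would move the number beyond the scatter, or whether any group placed here can do so. From the compounds shown here alone, all three values also come from this assay alone, so it remains open whether formyl, acetyl and the tert-butoxy carbonyl group would stand equally level on another cell line.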